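A few compounds are considered here, and "the series" means these few. Any claim that something is new, unique, unknown or untested is made for them only; others in the source may bear on it.

Compound 1 `Cn1ccc2c(Oc3ccc(NC(=O)c4cc5cccnc5n(-c5ccccc5)c4=O)cc3)ncnc21` and compound 2 `Cn1ccc2c(Oc3ccc(NC(=O)c4cc5cccnc5n(-c5ccccc5)c4=O)cc3F)ncnc21` share one core. In a functional assay on MCF7 cells (Homo sapiens) for cytotoxicity, read by MTT assay, with a stated time of 72 h (on this read-out higher numbers stand for weaker inhibition and lower numbers for stronger inhibition), compound 1 gives 88400 nM, and compound 2 gives 73400 nM. The difference between them is fluoro in place of hydrogen on an aromatic carbon, and the step it made was a 1.2-fold lower number from compound 1 to compound 2 (0.08 log units; within the scatter). Compound 3 `O=C(Nc1ccc(Oc2ncnc3[nH]ccc23)c(F)c1)c1cc2cccnc2n(-c2ccc(Br)cc2)c1=O` rests on another core; how the two cores differ is not broken down here. In this assay compound 3 gives 27000 nM. Compound 4 `O=C(Nc1ccc(Oc2ncnc3[nH]ccc23)c(F)c1)c1cc2cccnc2n(-c2ccc(Br)cc2F)c1=O` has not been measured; it differs from compound 3 by fluoro in place of hydrogen on an aromatic carbon. This is the same kind of change as that from compound 1 to compound 2, but the surroundings differ: there the entering fluoro sits meta to a large group, here meta to a bromo group. Because a 1.2-fold lower number from compound 1 to compound 2 (0.08 log units; within the scatter) stayed within the scatter, the expected step is a 1.2-fold lower number from compound 3 to compound 4 (0.07 log units; within the scatter). Compound 4 is thus expected to give 23000 nM in this assay, with a range from 9000 nM to 60000 nM.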

Compound 4, half-maximal inhibitory concentration: 102000 nM
Beside the measured number, compound 4's estimate is 4.4-fold (0.65 log units) below it, outside the stated range (above it).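

In this assay, fluoro in place of hydrogen, here 4-bromophenyl to 4-bromo-2-fluorophenyl, gave a 3.8-fold higher number from compound 3 to compound 4 (0.58 log units; beyond the scatter), and this step did not match the earlier one: the same change on two cores in this assay, a 1.2-fold lower number (0.08 log units; within the scatter) from compound 1 to compound 2 and a 3.8-fold higher number (0.58 log units; beyond the scatter) from compound 3 to compound 4, 4.5-fold (0.66 log units) apart, beyond the scatter of two such steps. In this series, then, the size of the step on the core of compound 1 did not carry over to the core of compound 3. For the compounds shown here, with only two pairs, which also differ in the surroundings of the entering fluoro, the data do not show which difference matters or give any general rule.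

From the compounds shown here alone, it remains open whether a chloro or methoxy group in that same place would give a similar step. Also open, going by these compounds, is whether fluoro would give such a step without the bromo group.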